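From isopropyl to allyloxy on a carbonyl carbon

The source may hold more compounds than are shown below. What is called first, only, known or untested is meant among the compounds shown, and "the series" means these compounds.

Compound 1 `O=C(OCc1ccccc1)SCCCCCCNC(=O)c1cc(-c2ccncc2)n[nH]1` gives 8370 nM
Compound 2 `CC(C)C(=O)SCCCCCCNC(=O)c1cc(-c2ccncc2)n[nH]1` gives 15200 nM
Compound 3 `O=C(NCCCCCCS)c1cc(-c2ccc(-c3ccccc3)cc2)n[nH]1` gives > 50000 nM

Among the compounds with values here, all three were tested in a functional assay on MCF7 cells (Homo sapiens) for inhibition, read by MTT assay, with a stated time of 96 h (a higher number here means a weaker inhibitor of growth, a lower number a stronger inhibitor of growth), and compound 2 lies within the scatter of compound 1, the only other true number. Compound 3 reports > 50000 nM as a limit of the assay. Compound 4 `C=CCOC(=O)SCCCCCCNC(=O)c1cc(-c2ccncc2)n[nH]1` differs from compound 2 as follows: allyloxy in place of isopropyl on a carbonyl carbon with allyloxy in place of isopropyl on a carbonyl carbon. Within the data shown here, one measured step bears on this place, the exchange of benzyloxy for isopropyl, which gave a 1.8-fold higher number from compound 1 to compound 2 (0.26 log units; within the scatter) and so stayed within the scatter. On that step from compound 1, no shift beyond the scatter is expected in this assay for the new group. The expected move is a 1.4-fold lower number from compound 2 to compound 4 (0.14 log units; within the scatter) and no more. Compound 4 is estimated at 11000 nM (expected range 4500 nM to 26000 nM).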

Compound 4, concentration for 50% growth inhibition: 12600 nM
Compound 4: middle estimate off by 1.1-fold (0.06 log units), on the low side; low and high end bracket the measured number.
By their numbers in this assay, from the lowest: compounds 1, 4 and 2 (each within the scatter of the next). At a limit, above all of these: compound 3.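

With a third group on the carbonyl carbon bound to sulfur, this assay shows a 1.2-fold lower number from compound 2 to compound 4 (0.08 log units; within the scatter) for allyloxy in place of isopropyl, and a 1.5-fold higher number from compound 1 to compound 4 (0.18 log units; within the scatter) for vinyl in place of phenyl on the saturated chain carbon. Benzyloxy, isopropyl and allyloxy thus all lie within the scatter of one another at this place, where earlier only one such pair could be read. Nothing available explains why these groups read so alike. Going by these compounds, whether an amine or a methyl on this carbonyl carbon would also stay within the scatter remains open.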